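Sulfonyl for carbonyl on the ring nitrogen of compound 2

This account rests on a few compounds, and the source may have more. Where it says the series, first, only, none or still open, it means among the compounds named here.

Two members of the series have been measured in a functional assay on A549 cells (Homo sapiens) for antiproliferative activity, read by MTT assay, with a stated time of 72 h; on this read-out lower numbers stand for stronger inhibition and higher numbers for weaker inhibition. Compound 1 `CN(C(=O)C(C)(C)C)c1ccc2[nH]c(-c3n[nH]c4ccccc34)cc2n1` gives 24400 nM. Compound 2 `COc1ccc(C(=O)N(C)c2ccc3[nH]c(-c4n[nH]c5ccccc45)cc3n2)cc1` gives 14600 nM. Going by the values given here, the only measured step, a 1.7-fold lower number from compound 1 to compound 2 (0.22 log units; within the scatter), exchanges the group on the carbonyl carbon and stays within the scatter. Compound 2 thus holds the lower of two numbers, with compound 1 within the scatter of it, so no order between the two can be stated.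

Compound 3 `CN(c1ccc2[nH]c(-c3n[nH]c4ccccc34)cc2n1)S(=O)(=O)c1ccc(Cl)cc1` is not yet measured. It differs from compound 2 by (4-chlorophenyl)sulfonyl in place of (4-methoxyphenyl)carbonyl on a nitrogen on an aromatic ring. Among the compounds with values here, the measured step bears on this only in part: it shows that exchanging the group on the carbonyl carbon left the number unchanged beyond the scatter, but no measured pair exchanges the carbonyl itself for a sulfonyl. With nothing in the series pointing either way, no step beyond the scatter is expected in this assay. Compound 3 is therefore estimated at 15000 nM, within 5000 nM to 45000 nM. The expected step of a 1.0-fold higher number from compound 2 to compound 3 (0.01 log units; within the scatter) is accordingly small.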

Compound 3, half-maximal inhibitory concentration: 18200 nM
Compound 3: middle estimate off by 1.2-fold (0.08 log units), on the low side, and the stated range covers the measured number.
By their numbers in this assay, from the lowest: compounds 2, 3 and 1 (each within the scatter of the next).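

In this assay, (4-chlorophenyl)sulfonyl in place of (4-methoxyphenyl)carbonyl on this nitrogen gives a step within the scatter (a 1.2-fold higher number from compound 2 to compound 3 (0.10 log units; within the scatter)), and the same group in place of (tert-butyl)carbonyl also stays within it (a 1.3-fold lower number from compound 1 to compound 3 (0.13 log units; within the scatter)). Going by these compounds alone, this is the first read on the carbonyl itself: among compounds 1, 2 and 3, a sulfonyl serves on this nitrogen without a step beyond the scatter, although the exchange also changes the aryl group, so the two parts cannot be separated. No supporting data explain this flat result.

The partners (4-methoxyphenyl)sulfonyl and (4-chlorophenyl)carbonyl would be needed to separate the two parts of the exchange. Also open, from the compounds shown here alone, is whether a different kind of group on this nitrogen, such as a carboxylic acid or an amine on a longer chain, would move the number beyond the scatter.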